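Series notes: one methoxy step, repeated on a second core

A few compounds are considered here, and "the series" means these few. Any claim that something is new, unique, unknown or untested is made for them only; others in the source may bear on it.

Measured so far:
compound 1 `COc1ccc(-c2cc(/C=C/C(=O)c3ccc(N)cc3)[nH]n2)cc1`, 90%
compound 2 `COc1ccc(C(=O)/C=C/c2cc(-c3cc(OC)c(OC)c(OC)c3)n[nH]2)cc1OC`, 81%
compound 3 `COc1ccc(-c2cc(/C=C/C(=O)c3ccc(N)cc3)[nH]n2)cc1OC`, 96%

In a functional assay on UACC-257 cells (Homo sapiens) for cytotoxicity, read by sulforhodamine B assay, with a stated time of 48 h, tested at 1 uM (a higher number here means a weaker effect of the compound at the concentration tested, a lower number a stronger effect), compound 1 gives 90% and compound 3 gives 96%; the change between them is methoxy in place of hydrogen on an aromatic carbon, and the step is a number 6 percentage points higher from compound 1 to compound 3 (within the scatter). Compound 2 gives 81% in this assay; the difference between the core of compound 2 and the core of compound 1 is not broken down here. Compound 4 `COc1cc(C(=O)/C=C/c2cc(-c3cc(OC)c(OC)c(OC)c3)n[nH]2)cc(OC)c1OC` is not yet measured. From compound 2 it differs by methoxy in place of hydrogen on an aromatic carbon. This is the same kind of change as from compound 1 to compound 3, though here the place is also meta to a methoxy group (2 heavy atoms). For compound 4 a step of about the same small size is expected, a number 6 percentage points higher from compound 2 to compound 4 (within the scatter), resting on a number 6 percentage points higher from compound 1 to compound 3 (within the scatter). Compound 4 is therefore estimated at 87%, most likely between 75% and 98%.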

Compound 4, a percentage reported as activity, at one concentration (the size of the read-out at that concentration, not a potency): 85%
Compound 4: middle estimate off by 2 percentage points, on the high side, within the range that was stated.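

In this assay, methoxy in place of hydrogen on an aromatic carbon gives a number 4 percentage points higher from compound 2 to compound 4 (within the scatter). Set beside the earlier step, the change carries from one core to the other without a visible difference: the same change on two cores in this assay, a number 6 percentage points higher (within the scatter) from compound 1 to compound 3 and a number 4 percentage points higher (within the scatter) from compound 2 to compound 4, 2 percentage points apart, within the scatter of two such steps Since both steps lie within the scatter, the two cores agree only in showing no clear effect of this change at the single concentration tested; this shows neither a small real shift nor how the change would behave on any other core.

Open, as far as these compounds go, is whether a different group at this place, such as a hydroxyl or a carboxylic acid, would move the read-out beyond the scatter. Also open, from the compounds shown here alone, is how the two cores themselves compare, as they differ in more than one place.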